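This account rests on a few compounds, and the source may have more. Where it says the series, first, only, none or still open, it means among the compounds named here.

Working notes on the series. Compound 1 `Cc1c(COCCCCO)[nH]c2ccccc2c1=O` was put into an in vitro ADME assay on microsomes from liver (Mus musculus) for metabolic stability, tested at 0.2 uM (a lower number here means slower removal, a higher number faster removal of the compound), but for compound 1 the result is "not determined" (no result reported). Compound 2 `Cc1c(COc2cccc(OCC3CCOCC3)n2)[nH]c2ccccc2c1=O` gives 984 mL/min/kg in this assay. Compound 3 `O=c1cc(COc2cccc(OCC3CCOCC3)c2)[nH]c2ccccc12` gives 197 mL/min/kg in this assay, which is the lowest of the two numbers reported so far; compound 2 sits at a higher number, a gap beyond the scatter of the method. Compound 4 `Cc1c(COc2cccc(OCC3CCOCC3)c2)[nH]c2ccccc2c1=O` has not yet been run. Compound 4 differs from compound 3 in one place: methyl in place of hydrogen on an aromatic carbon. For the measured compounds named here, no measured pair in the set shares exactly this change, so the size of the step can only be guessed from the numbers at hand. Compound 2 carries the same methyl and gives the higher number, so the methyl is expected to move the number upward, and the step from compound 3 to compound 4 is estimated at a 2.0-fold higher number from compound 3 to compound 4 (0.31 log units; beyond the scatter), likely at the edge of the scatter or somewhat beyond it. Compound 4 is thus expected to give about 400 mL/min/kg, within a range of 150 mL/min/kg to 1000 mL/min/kg.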

Compound 4, clearance: 420 mL/min/kg
Estimate against measurement, compound 4: 1.1-fold (0.02 log units) below; measured number inside the range.
By their numbers in this assay, from the lowest: compound 3; then compound 4; then compound 2.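

In this assay, methyl in place of hydrogen on this aromatic carbon, two atoms from the ring nitrogen, now has a directly measured effect: a 2.1-fold higher number from compound 3 to compound 4 (0.33 log units; beyond the scatter), a modest step beyond the scatter. This single added carbon is therefore enough to separate the two compounds, leaving the hydrogen-bearing compound 3 with the lowest number in the set, while compound 4 at 420 mL/min/kg still sits below compound 2 at 984 mL/min/kg. Nothing available explains why the number rises with this change.

The compounds shown leave open how an ethyl group, a fluorine atom or a methoxy group on this same carbon would compare with hydrogen and methyl. They also leave open whether the step keeps its size when the side chain carries an amine or a carboxylic acid.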